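The compounds below may be only part of what the source reports. "The series", "measured", "known", "first", "only" and "open" are said of these compounds alone.

Working notes on the series. Compound 1 `COc1cc(-c2cc(/C=C/C(=O)c3ccc(Cl)c(Cl)c3)[nH]n2)cc(OC)c1OC` gives 104% in a functional assay on SK-OV-3 cells (Homo sapiens) for cytotoxicity, read by sulforhodamine B assay, with a stated time of 48 h, tested at 0.1 uM; a higher number here means a weaker effect of the compound at the concentration tested, a lower number a stronger effect. Compound 2 `COc1ccc(-c2cc(/C=C/C(=O)c3ccc(N)cc3)[nH]n2)cc1OC` gives 102% in this assay. Of the two numbers, compound 1 holds the larger one, but the gap to compound 2 lies within the usual scatter, so the two compounds cannot be told apart, and neither shows a measurable effect at the concentration tested. For the measured compounds named here, no step between two measured compounds that differ in one place is available; what follows rests on the two values alone and on the structural change.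

Compound 3 `COc1cc(-c2cc(/C=C/C(=O)c3ccc(F)c(F)c3)[nH]n2)cc(OC)c1OC` differs from compound 1 in one place: 3,4-difluorophenyl in place of 3,4-dichlorophenyl on a carbonyl carbon. With both measured compounds reading near full activity, the expected step of a number 4 percentage points lower from compound 1 to compound 3 (within the scatter) is none beyond the scatter. For compound 3 the estimate in this assay is 100%, with a range from 85% to 112%.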

Compound 3, a percentage reported as activity, at one concentration (the size of the read-out at that concentration, not a potency): 99%
The estimate for compound 3 lay 1 percentage points above the measured number, and the stated range covers the measured number.
By their numbers in this assay, from the lowest: compounds 3, 2 and 1 (each within the scatter of the next).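

For the compounds shown here, the first readable step at this position, a number 5 percentage points lower from compound 1 to compound 3 (within the scatter), shows that 3,4-difluorophenyl in place of 3,4-dichlorophenyl on a carbonyl carbon leaves the read-out in this assay unchanged beyond the scatter. Exchanging one halogen pair for the other therefore does not separate the two compounds, and compound 3 at 99% shows no measurable effect at the concentration tested. Nothing measured on these compounds bears on why this step is so small.

On these data alone, whether a nitrile or a carboxylic acid in place of the halogens on this phenyl ring would move the number remains open. With only one concentration shown, it is also open whether these compounds differ from one another at higher concentrations.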